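The source may report more compounds than this note shows. Statements on the series, on what has been measured and on what is new or still open speak of the compounds shown alone.

Three compounds that share one core were tested in an assay on COS-7 cells for agonist activity at Free fatty acid receptor 1 (Homo sapiens), read by scintillation counting and inositol phosphate accumulation, with a stated time of 90 min; on this read-out lower numbers stand for an effect already at smaller amounts and higher numbers for an effect only at larger amounts of compound. Compound 1 `Cc1ccc(Nc2nc(N)nc(COc3ccc4c(C)cc(=O)oc4c3)n2)cc1` gives 1790 nM. Compound 2 `Cc1cc(=O)oc2cc(OCc3nc(N)nc(Nc4cccc(Cl)c4)n3)ccc12` gives 1110 nM, and compound 3 `Cc1ccc(Nc2nc(N)nc(COc3ccc4c(C)cc(=O)oc4c3)n2)cc1Cl` gives 140 nM. The difference between compound 1 and compound 2 amounts to a 1.6-fold lower number from compound 1 to compound 2 (0.21 log units; within the scatter). Compound 3 and compound 1 differ only in the part described by hydrogen in place of chloro on an aromatic carbon, and the step is a 13-fold lower number from compound 1 to compound 3 (1.11 log units; beyond the scatter). Compound 3 and compound 2 differ by hydrogen in place of methyl on an aromatic carbon, a change that gives a 7.9-fold higher number from compound 3 to compound 2 (0.90 log units; beyond the scatter).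

Compound 4 `Cc1ccc(Nc2nc(N)nc(COc3ccc4ccc(=O)oc4c3)n2)cc1` has not yet been measured. It differs from compound 1 by hydrogen in place of methyl on an aromatic carbon. For the measured compounds named here, this is the same kind of change as the one from compound 3 to compound 2, but not the same: there the methyl sat on a ring of carbon only, ortho to a chloro group and para to a large group, whereas here it sits on a ring with one oxygen within a fused system, ortho and meta to a fused ring and opposite the ring oxygen. Going by the values given here, the only measured instance of removing a methyl is the step of a 7.9-fold higher number from compound 3 to compound 2 (0.90 log units; beyond the scatter), so the expectation rests on one example at a different place. For compound 4 the step from compound 1 is expected to be a 1.8-fold higher number from compound 1 to compound 4 (0.25 log units; within the scatter), smaller than the measured one because a 7.9-fold higher number from compound 3 to compound 2 (0.90 log units; beyond the scatter) was made on a different ring. Compound 4 is therefore estimated at 3200 nM, with a range from 1100 nM to 9500 nM.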

Compound 4, half-maximal effective concentration: 1280 nM
The estimate for compound 4 lay 2.5-fold (0.40 log units) above the measured number, and the stated range covers the measured number.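

In this assay, for the compounds shown here, taking the methyl off the ring with one oxygen gives a 1.4-fold lower number from compound 1 to compound 4 (0.15 log units; within the scatter), so at this carbon the exchange of methyl for hydrogen produces no step that can be told apart from the scatter. Described only as hydrogen in place of methyl on an aromatic carbon, the change does not carry a single size from one compound pair to the other, since the two results differ clearly: the same change on two cores in this assay, a 7.9-fold higher number (0.90 log units; beyond the scatter) from compound 3 to compound 2 and a 1.4-fold lower number (0.15 log units; within the scatter) from compound 1 to compound 4, 11-fold (1.04 log units) apart, beyond the scatter of two such steps This shows that the earlier result cannot simply be transferred to a new place in this series, but it does not explain the gap: the methyl sits on a ring of carbon only in one pair and on the ring with one oxygen in the other, the surrounding structures differ as well, and each case rests on a single pair.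

The compounds shown leave open whether the methyl on the ring with one oxygen could also be removed without a clear step from a compound that carries the chloro group of compound 3. They also leave open how that same carbon would respond to an ethyl group, a methoxy group, an amine or a carboxylic acid.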